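Methoxy in Place of Chloro: Compound 3 to Compound 4

This account rests on a few compounds, and the source may have more. Where it says the series, first, only, none or still open, it means among the compounds named here.

Three measured compounds share one core and differ only in the chlorophenyl on the sulfonyl sulfur. In an assay on isolated protein for inhibition of malate dehydrogenase, mitochondrial (Sus scrofa), with stated times of 45 min and 30 min (a higher number here means a weaker inhibitor, a lower number a stronger inhibitor), compound 1 `O=S(=O)(Nc1ccc2oc(-c3ccccc3)nc2c1)c1ccc(Cl)cc1` reaches only a limit, > 63000 nM. Compound 2 `O=S(=O)(Nc1ccc2oc(-c3ccccc3)nc2c1)c1cccc(Cl)c1` likewise gives a limit, > 63000 nM. Compound 3 `O=S(=O)(Nc1ccc2oc(-c3ccccc3)nc2c1)c1ccccc1Cl` also stands at a limit, > 63000 nM. The steps a step that the two limits leave unreadable from compound 1 to compound 2, a step that the two limits leave unreadable from compound 1 to compound 3 and a step that the two limits leave unreadable from compound 2 to compound 3 cannot be sized because of the limit of > 63000 nM in this assay, at which 3 of the 3 values shown sit. Compound 4 `COc1ccccc1S(=O)(=O)Nc1ccc2oc(-c3ccccc3)nc2c1` carries methoxy in place of chloro on an aromatic carbon. For the measured compounds named here, no measured step gives a readable size, so nothing beyond the limit can be drawn from them, and the change is expected to leave compound 4 where compound 3 stands. Compound 4 is therefore estimated at 80000 nM, with a range from 30000 nM to 300000 nM, an expected step that the limit leaves unreadable from compound 3 to compound 4.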

Compound 4, half-maximal inhibitory concentration: > 63000 nM
Compound 4: a limit, no number; the forecaster's own chance of this, stated with the estimate: 80%; the middle value does not contradict the limit.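

Compound 4, like compound 1, compound 2 and compound 3, gives only a limit in this assay, so no step to compound 4 can be read: the limit of > 63000 nM in this assay, at which 4 of the 4 values shown sit.

How strongly any of these compounds inhibits, and whether the group on the sulfonyl sulfur matters, stays open.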